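Aryl variation on the ring amine nitrogen: toward compound 4

The source may hold more compounds than are shown below. What is called first, only, known or untested is meant among the compounds shown, and "the series" means these compounds.

Measured so far:
compound 1, `Nc1scc(CN2CCN(c3cc(F)cc(F)c3)CC2)c1C(=O)c1ccc(Cl)cc1`, -5%
compound 2, `Nc1scc(CN2CCN(c3c(F)cccc3F)CC2)c1C(=O)c1ccc(Cl)cc1`, -23%
compound 3, `Nc1scc(CN2CCN(c3cccc(F)c3F)CC2)c1C(=O)c1ccc(Cl)cc1`, -5.2%

All three share one core and differ only in the difluorophenyl on an amine nitrogen in a ring. In a functional assay on CHO cells with adenosine receptor A1 (Homo sapiens) as the target, read by cAMP accumulation and immunoassay, with a stated time of 6 min, tested at 0.1 uM (on this read-out higher numbers stand for a weaker effect at the one concentration tested and lower numbers for a stronger effect), compound 3 gives -5.2%, the second highest of the three numbers. Compound 1 is the nearest neighbour, with a number 0.2 percentage points lower from compound 1 to compound 3 (within the scatter); compound 2 is the furthest, with a number 17.8 percentage points higher from compound 2 to compound 3 (beyond the scatter).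

Compound 4, `Nc1scc(CN2CCN(c3cccc(Cl)c3)CC2)c1C(=O)c1ccc(Cl)cc1`, is not yet measured. The change from compound 3 is 3-chlorophenyl in place of 2,3-difluorophenyl on an amine nitrogen in a ring.

Among the measured compounds shown here, the steps that bear on this are the aryl swaps on the same ring nitrogen. Of those, a number 18 percentage points lower from compound 1 to compound 2 (beyond the scatter) and a number 17.8 percentage points higher from compound 2 to compound 3 (beyond the scatter) were beyond the scatter but modest, while a number 0.2 percentage points lower from compound 1 to compound 3 (within the scatter) was within it. For the measured compounds named here, no measured step replaces a fluorine-bearing aryl with a chlorine-bearing one, so the direction of the step to compound 4 is open; the measured range suggests at most a modest move. For compound 4 the expected step is a number 1.8 percentage points lower from compound 3 to compound 4 (within the scatter), close to nothing beyond the scatter. Compound 4 is therefore estimated at -7% in this assay, within -28% to 12%.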

Compound 4, a percentage reported as activity, at one concentration (the size of the read-out at that concentration, not a potency): -20%
Beside the measured number, compound 4's estimate is 13 percentage points above it; low and high end bracket the measured number.
By their numbers in this assay, from the lowest: compounds 2 and 4 (each within the scatter of the next); then compounds 3 and 1 (each within the scatter of the next).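

In this assay, the 3-chlorophenyl on the amine nitrogen in a ring separates from two of the difluorophenyl compounds, with a number 14.8 percentage points lower from compound 3 to compound 4 (beyond the scatter) and a number 15 percentage points lower from compound 1 to compound 4 (beyond the scatter), while a number 3 percentage points higher from compound 2 to compound 4 (within the scatter) places it level with the 2,6-difluorophenyl compound. The lower level of the read-out at this position is therefore no longer unique to the 2,6-difluorophenyl group: two aryl groups with different halogens and different substitution now share it, and the four compounds fall into two levels, compounds 2 and 4 on one and compounds 1 and 3 on the other. No measurement or other supporting data offers an explanation for this grouping.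

The change to compound 4 swaps fluorine for chlorine and also reduces the halogens on the aryl from two to one, so the two contributions remain inseparable here; a 3-fluorophenyl or an unsubstituted phenyl on the same nitrogen would bear on that. Also open, from the compounds shown here alone, is whether the two levels seen at this single concentration would hold as a difference in potency across a full concentration range.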